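A few compounds are considered here, and "the series" means these few. Any claim that something is new, unique, unknown or untested is made for them only; others in the source may bear on it.

Four compounds share one core and differ only in the dichlorophenyl at one end. In an ADME assay on NHDF cells (Homo sapiens) for cytotoxicity, read by MTT assay, with a stated time of 72 h (on this read-out higher numbers stand for weaker inhibition and lower numbers for stronger inhibition), compound 1 `COc1cccc(/C=C2\CCC/C(=C\c3cccc(Cl)c3Cl)C2=O)c1OC` gives no number but a limit, > 50000 nM, which is the limit of > 50000 nM in this assay, at which 1 of the 3 values shown sits. Compound 2 `COc1cccc(/C=C2\CCC/C(=C\c3ccc(Cl)cc3Cl)C2=O)c1OC` gives 49200 nM in this assay. The change between them is 2,4-dichlorophenyl in place of 2,3-dichlorophenyl on a double-bonded chain carbon bound to a double-bonded ring carbon, and it gave an at least 1.0-fold lower number from compound 1 to compound 2 (0.00 log units; that floor lies within the scatter). Compound 3 `COc1ccc(/C=C2\CCC/C(=C\c3cccc(Cl)c3Cl)C2=O)cc1OC` gives 18500 nM in this assay; the difference between the core of compound 3 and the core of compound 1 is not broken down here. Compound 4 `COc1ccc(/C=C2\CCC/C(=C\c3ccc(Cl)cc3Cl)C2=O)cc1OC` has not yet been measured. It repeats the same change on compound 3, (2,4-dichlorophenyl in place of 2,3-dichlorophenyl on a double-bonded chain carbon bound to a double-bonded ring carbon). The expected step rests on the measured one, an at least 1.0-fold lower number from compound 1 to compound 2 (0.00 log units; that floor lies within the scatter), and is estimated as a 1.1-fold lower number from compound 3 to compound 4 (0.04 log units; within the scatter). Compound 4 is thus expected at 17000 nM, between 8000 nM and 40000 nM.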

Compound 4, half-maximal inhibitory concentration: > 50000 nM
Compound 4: only a limit was reported; the forecaster's own chance of this, stated with the estimate: 5%; middle value at least 2.9-fold (0.46 log units) away from the limit.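

In this assay, putting 2,4-dichlorophenyl in place of 2,3-dichlorophenyl gave an at least 2.7-fold higher number from compound 3 to compound 4 (0.43 log units; beyond the scatter), so on this core the change clearly weakened the effect on the cells. The change therefore did not carry over from one core to the other with the same size: the same change on two cores in this assay, an at least 1.0-fold lower number (0.00 log units; that floor lies within the scatter) from compound 1 to compound 2 and an at least 2.7-fold higher number (0.43 log units; beyond the scatter) from compound 3 to compound 4, at least 2.7-fold (0.43 log units) apart, beyond the scatter of two such steps

Compound 1 and compound 4 each gave a limit and not a number, so the true size of both steps and of the gap between them stays unknown, and the data do not show why the cores differ: the limit of > 50000 nM in this assay, at which 2 of the 4 values shown sit.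

Going by these compounds, whether either pattern of results holds on a third core remains open. So does what a phenyl ring carrying a single chlorine, an amine or a carboxylic acid would give in this assay.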